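Pentafluoroethyl Replaces Dimethylamino in a Benzamide Series

This account rests on a few compounds, and the source may have more. Where it says the series, first, only, none or still open, it means among the compounds named here.

Of the compounds shown here, three have been measured in an ADME assay on microsomes from liver (Rattus norvegicus, strain Sprague-Dawley) for metabolic stability, read by HPLC, using NADPH, with stated times of 5 min and 60 min, tested at 10 uM; on this read-out lower numbers stand for a shorter-lived compound and higher numbers for a longer-lived compound. Compound 1 `CCS(=O)(=O)Nc1ccc(CNC(=O)c2ccc(C(C)(C)C)cc2)c(Cl)c1` gives 0.783 h, compound 2 `CC(C)(C)c1ccc(C(=O)NCc2ccc(NS(C)(=O)=O)cc2F)cc1` gives 0.483 h, and compound 3 `CN(C)c1ccc(C(=O)NCc2ccc(NS(C)(=O)=O)cc2Cl)cc1` gives 0.883 h. Compound 3 has the highest number of the three, yet its gaps to compound 1 and to compound 2 both lie within the scatter, so no ordering among them can be claimed. Compound 4 `CS(=O)(=O)Nc1ccc(CNC(=O)c2ccc(C(F)(F)C(F)(F)F)cc2)c(Cl)c1` is not yet measured; it differs from compound 3 by 1,1,2,2,2-pentafluoroethyl in place of dimethylamino on an aromatic carbon. For the measured compounds named here, no measured pair shows this change. Compound 4 is expected to land near its relatives, with a 1.1-fold higher number from compound 3 to compound 4 (0.05 log units; within the scatter) not beyond the scatter, because compound 1 with the same core gives 0.783 h. Compound 4 is therefore estimated at 1 h, within 0.5 h to 2 h.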

Compound 4, half-life: 1.6 h
Estimate against measurement, compound 4: 1.6-fold (0.20 log units) below; the range from low to high includes it.
By their numbers in this assay, from the lowest: compounds 2, 1, 3 and 4 (each within the scatter of the next, the first and the last beyond it).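

For the compounds shown here, at this position, para to a large group, the first measured pair for this change gives a 1.8-fold higher number from compound 3 to compound 4 (0.26 log units; within the scatter) in this assay. Dimethylamino, with 3 heavy atoms, can thus give way to 1,1,2,2,2-pentafluoroethyl, with 7 heavy atoms and no hydrogen-bond acceptor, without a step beyond the scatter. No measurement of any property of these groups bears on this result. The compounds shown leave open how a smaller fluorinated group such as trifluoromethyl, or a carboxylic acid, would read at this position. They also leave open whether this step would hold on the core of compound 2.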